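The source may report more compounds than this note shows. Statements on the series, on what has been measured and on what is new or still open speak of the compounds shown alone.

In a functional assay, read by spectrophotometry, tested at 100 uM (a higher number here means a weaker inhibitor, a lower number a stronger inhibitor), compound 1 `O=C(/C=C/c1cccc2ccccc12)c1cccc(NC(=O)c2cc(-c3ccncc3)n[nH]2)c1` gives 72100 nM and compound 2 `O=C(/C=C/c1ccc(F)cc1)c1cccc(NC(=O)c2cc(-c3ccncc3)n[nH]2)c1` gives 58700 nM while compound 3 `O=C(/C=C/c1cccs1)c1cccc(NC(=O)c2cc(-c3ccncc3)n[nH]2)c1` gives 70000 nM so compound 3 stands within the scatter of both others. Compound 4 `O=C(/C=C/c1ccco1)c1cccc(NC(=O)c2cc(-c3ccncc3)n[nH]2)c1` differs from compound 3 at one place, with furan-2-yl in place of thiophen-2-yl on a double-bonded chain carbon bound to a double-bonded chain carbon. Three measured steps at this same place bear on the change: a 1.2-fold lower number from compound 1 to compound 2 (0.09 log units; within the scatter) and a 1.0-fold lower number from compound 1 to compound 3 (0.01 log units; within the scatter) and a 1.2-fold higher number from compound 2 to compound 3 (0.08 log units; within the scatter) and none of them leaves the scatter. In this assay no step beyond the scatter is therefore expected, and the size of the expected step is small (a 1.1-fold lower number from compound 3 to compound 4 (0.03 log units; within the scatter)). The estimated value for compound 4 is 65000 nM (expected range 36000 nM to 110000 nM).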

Compound 4, half-maximal inhibitory concentration: 72300 nM
For compound 4 the middle estimate is 1.1-fold (0.05 log units) below the measured one; the range from low to high includes it.
By their numbers in this assay, from the lowest: compounds 2, 3, 1 and 4 (each within the scatter of the next).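

In this assay, furan-2-yl in place of thiophen-2-yl on a double-bonded chain carbon gives no step beyond the scatter (a 1.0-fold higher number from compound 3 to compound 4 (0.01 log units; within the scatter)), so oxygen for sulfur in the five-membered aromatic ring leaves the number in place. The same holds when furan-2-yl replaces the other two groups (a 1.2-fold higher number from compound 2 to compound 4 (0.09 log units; within the scatter); a 1.0-fold higher number from compound 1 to compound 4 (0.00 log units; within the scatter)), so all four compounds now lie within the scatter of one another. Nothing measured here offers a reason for this.

Open, from the compounds shown here alone, is whether an amine or a carboxylic acid at this place would leave the scatter. Also open, going by these compounds, is how changes elsewhere on the shared core would move the number.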